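The source may report more compounds than this note shows. Statements on the series, on what has been measured and on what is new or still open speak of the compounds shown alone.

The study records an ADME assay on BJ cells (Homo sapiens) for cytotoxicity, read by CellTiter-Glo and resazurin assay, with a stated time of 72 h (a lower number here means that less compound is needed, a higher number that more compound is needed for the effect), for three compounds and leaves a fourth open. Compound 1 is `CC(=O)c1cccc(-c2ccc(C(=O)N(Cc3cccc(OCCCCCC(=O)O)c3)C(C)C)cc2)c1`. In this assay compound 1 reaches only the limit of the assay, > 26000 nM, rather than a number. Compound 2 is `CC(C)COc1cccc(-c2ccc(C(=O)N(Cc3cccc(OCCCCCC(=O)O)c3)C(C)C)cc2)c1`; it differs from compound 1 by isobutoxy in place of acetyl on an aromatic carbon. In this assay compound 2 likewise sits at a limit, > 26000 nM. The step in this assay is therefore a step that the two limits leave unreadable from compound 1 to compound 2. Compound 3 is `CCOC(=O)CCCCCOc1cccc(CN(C(=O)c2ccc(-c3cccc(C(C)=O)c3)cc2)C(C)C)c1`; its core differs from that of compound 1 by ethyl in place of hydrogen on an oxygen next to a carbonyl group. In this assay compound 3 also gives only a limit, > 26000 nM. The step in this assay here is a step that the two limits leave unreadable from compound 1 to compound 3. All three values share one feature: the limit of > 26000 nM in this assay, at which 3 of the 3 values shown sit.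

Compound 4, still to be measured, is `CCOC(=O)CCCCCOc1cccc(CN(C(=O)c2ccc(-c3cccc(OCC(C)C)c3)cc2)C(C)C)c1`. It differs from compound 3 by isobutoxy in place of acetyl on an aromatic carbon, and the place is described in the same words as for the change from compound 1 to compound 2, so this is the same change, now made on the core of compound 3. Among the measured compounds shown here, the step expected from compound 3 to compound 4 in this assay is a step that the limit leaves unreadable from compound 3 to compound 4, resting on the same change having read as a step that the two limits leave unreadable from compound 1 to compound 2 and on every value so far sitting at the limit of > 26000 nM in this assay, at which 3 of the 3 values shown sit. Compound 4 is accordingly estimated at 30000 nM, with an expected range from 15000 nM to 60000 nM, and most likely reported again only as a limit.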

Compound 4, half-maximal effective concentration: > 26000 nM
Compound 4 was reported as a limit; the forecaster's own chance of this, stated with the estimate: 85%; the middle value lies beyond the limit too.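

No new step can be read: the changes from compound 3 to compound 4 and from compound 2 to compound 4 each join two limits, so neither has a readable size. The compounds shown leave open whether either change, isobutoxy for acetyl or ethyl for hydrogen, makes any difference in this assay, since all four compounds rest at one value: the limit of > 26000 nM in this assay, at which 4 of the 4 values shown sit.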